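Swapping the amide-side aryl group in an inhibitor series

A few compounds are considered here, and "the series" means these few. Any claim that something is new, unique, unknown or untested is made for them only; others in the source may bear on it.

Measured so far:
- compound 1, `C[C@H](NC(=O)C(=O)NCc1ccc(Cl)cc1)C(=O)N[C@@H](CC(=O)O)C(=O)COc1c(F)c(F)cc(F)c1F`: 8.4 nM
- compound 2, `C[C@H](NC(=O)C(=O)NCC1(c2ccccc2)CC1)C(=O)N[C@@H](CC(=O)O)C(=O)COc1c(F)c(F)cc(F)c1F`: 27 nM

Both compounds share one core and differ only in the group attached to the saturated chain carbon bound to an amide-type nitrogen. In a functional assay on Jurkat cells (Homo sapiens) (on this read-out higher numbers stand for weaker inhibition and lower numbers for stronger inhibition), compound 1 gives 8.4 nM, while compound 2 gives 27 nM. Going by the values given here, the single measured step, a 3.2-fold higher number from compound 1 to compound 2 (0.51 log units; beyond the scatter), shows that the 1-phenylcyclopropyl group weakens inhibition relative to the 4-chlorophenyl group. Compound 2 therefore stands with the highest, that is the weakest, number of the two.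

Compound 3, `C[C@H](NC(=O)C(=O)NCc1cc(Cl)ccc1Cl)C(=O)N[C@@H](CC(=O)O)C(=O)COc1c(F)c(F)cc(F)c1F`, has not yet been measured. It differs from compound 2 in one place: 2,5-dichlorophenyl in place of 1-phenylcyclopropyl on a saturated chain carbon bound to an amide-type nitrogen. This change returns the substituent to a chlorinated phenyl ring, which resembles compound 1 more than compound 2. Among the compounds with values here, the only step that bears on it, a 3.2-fold higher number from compound 1 to compound 2 (0.51 log units; beyond the scatter), ran in the opposite direction, so reversing toward a chlorophenyl is expected to give a lower number. The expected step for compound 3 is a 2.7-fold lower number from compound 2 to compound 3 (0.43 log units; beyond the scatter). Compound 3 is therefore estimated at 10 nM, with a likely range from 4 nM to 30 nM.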

Compound 3, half-maximal inhibitory concentration: 4.3 nM
Beside the measured number, compound 3's estimate is 2.3-fold (0.37 log units) above it; measured number inside the range.
By their numbers in this assay, from the lowest: compounds 3 and 1 (each within the scatter of the next); then compound 2.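

In this assay, putting 2,5-dichlorophenyl in place of 1-phenylcyclopropyl on the saturated chain carbon bound to an amide-type nitrogen gives a 6.3-fold lower number from compound 2 to compound 3 (0.80 log units; beyond the scatter), so the weaker inhibition of compound 2 now shows up against two different chlorinated rings rather than only one. The other new comparison, 2,5-dichlorophenyl in place of 4-chlorophenyl, gives a 2.0-fold lower number from compound 1 to compound 3 (0.29 log units; within the scatter), which means that the second chlorine and the changed chlorine pattern make no difference here that can be told apart from ordinary assay scatter. No supporting measurement is available to explain either result.

Compound 2 differs from the chlorinated compounds both in having a cyclopropane ring and in lacking chlorine, so the compounds shown cannot separate these two features, and a 1-(4-chlorophenyl)cyclopropyl group would be the direct test. Also open, from the compounds shown here alone, is how a phenyl ring carrying a methoxy or trifluoromethyl group instead of chlorine would compare at this place, and whether an amine or a carboxylic acid on that ring would keep inhibition.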